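A few compounds are considered here, and "the series" means these few. Any claim that something is new, unique, unknown or untested is made for them only; others in the source may bear on it.

Values in a functional assay on U2OS cells (Homo sapiens) for cytotoxicity, read by MTT assay, with a stated time of 48 h; on this read-out higher numbers stand for weaker inhibition and lower numbers for stronger inhibition:
- compound 1 `Fc1cccc(-c2nc(Nc3ccc(Cl)cc3)c3cc(F)ccc3n2)c1`: 38400 nM
- compound 2 `Nc1cccc(Nc2nc(-c3cccc(F)c3)nc3ccc(F)cc23)c1`: 49700 nM
- compound 3 `Nc1ccccc1Nc1nc(-c2cccc(F)c2)nc2ccc(F)cc12`: 37900 nM

In this assay compound 3 at 37900 nM cannot be separated from the other two compounds, since its steps to both lie within the scatter. The next compound to read is compound 4 `Cc1ccccc1Nc1nc(-c2cccc(F)c2)nc2ccc(F)cc12`, which has methyl in place of amino on an aromatic carbon, ortho to a large group: methyl in place of amino on an aromatic carbon.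

Going by the values given here, no measured step makes this exact exchange, so the evidence is indirect. Three steps alter the aryl group on the nitrogen: a 1.3-fold higher number from compound 1 to compound 2 (0.11 log units; within the scatter), a 1.0-fold lower number from compound 1 to compound 3 (0.01 log units; within the scatter) and a 1.3-fold lower number from compound 2 to compound 3 (0.12 log units; within the scatter). All three are small and within the scatter. Compound 1 carries 4-chlorophenyl and no amino group, yet a 1.0-fold lower number from compound 1 to compound 3 (0.01 log units; within the scatter) shows no separation from compound 3. Of the compounds shown here, three are a thin basis, and none of them carries methyl, but nothing measured so far points to a real shift. The expected result is a 1.0-fold higher number from compound 3 to compound 4 (0.00 log units; within the scatter), with no step beyond the scatter in either direction. For compound 4 the estimated value is 38000 nM, with an expected range from 20000 nM to 70000 nM.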

Compound 4, half-maximal inhibitory concentration: > 50000 nM
Compound 4 gave a limit, no number (the forecaster's own chance of this, stated with the estimate: 10%); middle value at least 1.3-fold (0.11 log units) away from the limit.
By their numbers in this assay, from the lowest: compounds 3, 1 and 2 (each within the scatter of the next). At a limit, above all of these: compound 4.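

Compound 4, with 2-methylphenyl on the nitrogen, is the only compound here in this assay that gives a limit and not a number: the limit of > 50000 nM in this assay, at which 1 of the 4 values shown sits.

Read as floors, an at least 1.3-fold higher number from compound 3 to compound 4 (0.12 log units; that floor lies within the scatter) and an at least 1.3-fold higher number from compound 1 to compound 4 (0.11 log units; that floor lies within the scatter) both stay within the scatter, so methyl in place of amino at this position, ortho to a large group, is not shown to move the read-out, though a larger real step is not excluded; the step from compound 2 to compound 4 cannot be read. Compound 1 also has no amino group and still gives a number, so the absence of amino alone does not go with a limit in this small set.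

As far as these compounds go, how far the true value of compound 4 lies from those of compound 1 and compound 3 stays open, since the limit leaves the size of both steps unknown. a number no lower from compound 2 to compound 4 (the limit leaves the size open) is all that can be said of the remaining step.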